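The source may report more compounds than this note shows. Statements on the series, on what has been measured and on what is new or still open speak of the compounds shown alone.

Measured compounds:
Compound 1, `CN1CCN(c2ccc(/C=C3\Oc4cc(O)cc(O)c4C3=O)cc2)CC1`, gives 15.8% in an assay on isolated protein for inhibition of Amine oxidase [flavin-containing] A (Homo sapiens), read by fluorescence and spectrophotometry, with a stated time of 30 min, tested at 10 uM; a lower number here means less inhibition, a higher number more inhibition at the concentration tested (going by the name of the read-out).
Compound 2, `COc1cc(O)c2c(c1)O/C(=C\c1ccc(N(C)C)cc1)C2=O`, gives 20.7%.
Compound 3, `COc1cc(O)c2c(c1)O/C(=C\c1ccc(N3CCCCC3)cc1)C2=O`, gives 18.3%.

Compound 2 holds the largest of these three numbers, yet the gap to compound 3 and the gap to compound 1 both lie within the usual scatter, so the three read as much the same. For the measured compounds named here, the one measured step, a number 2.4 percentage points lower from compound 2 to compound 3 (within the scatter), swaps one amine for another on the outer ring and leaves the number essentially unchanged.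

Compound 4, `CN(C)c1ccc(/C=C2\Oc3cc(N(C)C)cc(O)c3C2=O)cc1`, is reached from compound 2 by a change elsewhere: dimethylamino in place of methoxy on an aromatic carbon. Going by the values given here, no measured step touches this position, so the prior steps give no direct guide; all that is known is that the shared core has so far given modest inhibition with every variation tried, and that the one change tried stayed within the scatter. On that basis compound 4 is expected to stay near compound 2, with a number 1.3 percentage points higher from compound 2 to compound 4 (within the scatter) as the expected step, not beyond the scatter. The estimate for compound 4 is 22%, in the range 8% to 38%.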

Compound 4, a percentage reported as inhibition, at one concentration (the size of the read-out at that concentration, not a potency): 16.8%
Estimate against measurement, compound 4: 5.2 percentage points above, and the stated range covers the measured number.
By their numbers in this assay, from the lowest: compounds 1, 4, 3 and 2 (each within the scatter of the next).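

In this assay, the change at this position, on an aromatic carbon para to a fused ring, gives a number 3.9 percentage points lower from compound 2 to compound 4 (within the scatter), so dimethylamino with its 3 heavy atoms and methoxy with its 2 leave the number within the scatter of each other. Until now only the outer ring had been varied, and this result extends the same flat picture to a second place on the shared core, although it rests on this single pair. Nothing measured here explains why the number holds, or shows whether the two groups act alike for the same reason.

Going by these compounds, whether a carboxylic acid or a longer chain such as butoxy at this place would lift the inhibition stays open. So does whether any group here can move the number beyond the scatter.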